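The source may hold more compounds than are shown below. What is called first, only, known or untested is meant among the compounds shown, and "the series" means these compounds.

Measured so far:
- Compound 1 `Nc1ncnc2c1ncn2[C@@H]1O[C@H](CN(CCCC(=O)O)Cc2cccc(C(=O)O)c2)[C@@H](O)[C@H]1O` gives > 250000 nM in an assay on cells for inhibition of Nicotinamide N-methyltransferase (Homo sapiens), with stated times of 10 min and 30 min (on this read-out higher numbers stand for weaker inhibition and lower numbers for stronger inhibition), a limit of the assay rather than a number.
- Compound 2 `NC(=O)CCCN(Cc1ccc2ccccc2c1)C[C@H]1O[C@@H](n2cnc3c(N)ncnc32)[C@H](O)[C@@H]1O` gives 112000 nM in this assay.

Among the measured compounds shown here, compound 2 thus holds the only number in hand; the other value is a limit, (the limit of > 250000 nM in this assay, at which 1 of the 2 values shown sits). Compound 3 `Nc1ncnc2c1ncn2[C@@H]1O[C@H](CN(CCCC(=O)O)Cc2ccc3ccccc3c2)[C@@H](O)[C@H]1O` has not yet been measured. It differs from compound 2 in one place: hydroxy in place of amino on a carbonyl carbon. For the measured compounds named here, no step between two measured compounds is available, so the size of this change can only be estimated from the two values shown. A modest loss of inhibition is expected, and compound 3 is expected to give about 160000 nM in this assay. The expected range runs from 50000 nM to 400000 nM. The expected step is a 1.4-fold higher number from compound 2 to compound 3 (0.15 log units; within the scatter), and there is a fair chance that compound 3 returns only a limit.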

Compound 3, half-maximal inhibitory concentration: > 250000 nM
Compound 3: only a limit was reported; the forecaster's own chance of this, stated with the estimate: 40%; middle value at least 1.5-fold (0.19 log units) from the limit.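

Replacing amino with hydroxy on this carbonyl carbon, which turns the carbamoyl end into a carboxy end, weakens inhibition in this assay, with an at least 2.2-fold higher number from compound 2 to compound 3 (0.34 log units; beyond the scatter). Among the compounds shown here, this is the first comparison that isolates this end of the chain, with the naphthalen-2-yl group unchanged; the two earlier compounds differ in more than one place. Both compounds with a carboxy end and no carbamoyl group now rest at the same assay limit: the limit of > 250000 nM in this assay, at which 2 of the 3 values shown sit.

The step from compound 1 to compound 3 cannot be read, so the naphthalen-2-yl and 3-carboxyphenyl groups remain unranked. On these data alone, it also remains open how far the loss extends and whether another group on this carbonyl carbon, such as a methyl ester or a hydroxamic acid, would give a lower number than carbamoyl.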